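Bromo in Place of Hydrogen and the Expected Maximal Response

A few compounds are considered here, and "the series" means these few. Any claim that something is new, unique, unknown or untested is made for them only; others in the source may bear on it.

Compound 1 `CN1CCC[C@H]1COc1cccnc1` stands highest of the two numbers measured in an assay on K177 cells with Neuronal acetylcholine receptor; alpha4/beta2 (Homo sapiens) as the target (a lower number here means a smaller maximal response, a higher number a larger maximal response), where compound 1 gives 100%. Within the data shown here, its only measured neighbour, compound 2 `Cc1ncccc1OC[C@@H]1CCCN1C`, gives 26.7%, and the step of a number 73.3 percentage points lower from compound 1 to compound 2 (beyond the scatter) came with methyl in place of hydrogen on an aromatic carbon. Compound 3 `CN1CCC[C@H]1COc1cncc(Br)c1` differs from compound 1 by bromo in place of hydrogen on an aromatic carbon. Among the measured compounds shown here, no measured step shares this change; the only ring substitution measured was large and downward. A smaller step in the same direction is therefore expected for compound 3, a number 40 percentage points lower from compound 1 to compound 3 (beyond the scatter). Compound 3 is estimated at 60%, within 20% to 100%.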

Compound 3, largest response reached (reported as maximum), in percent of the reference or control that the assay uses: 41.8%
Beside the measured number, compound 3's estimate is 18.2 percentage points above it, within the range that was stated.
By their numbers in this assay, from the lowest: compound 2; then compound 3; then compound 1.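

In this assay, bromo on this aromatic carbon, two atoms from the ring nitrogen, gives a number 58.2 percentage points lower from compound 1 to compound 3 (beyond the scatter), so a single heavy atom at this position is enough for a large loss of maximal response. With a number 73.3 percentage points lower from compound 1 to compound 2 (beyond the scatter), both ring substitutions shown now lower the response, although they differ in group and place. Nothing available here accounts for either step. Going by these compounds, whether chloro, fluoro or an amine on this same carbon would hold the response near that of compound 1 stays open. So does what bromo would do on the other ring carbons.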